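A few compounds are considered here, and "the series" means these few. Any claim that something is new, unique, unknown or untested is made for them only; others in the source may bear on it.

Compound 1, `Cn1c(-c2ccccc2Cl)cnc1NC(=O)c1ccc(F)cc1`, in a toxicity assay on THP-1 cells (Homo sapiens) for inhibition (a lower number here means that less compound is tolerated, a higher number that more compound is tolerated), gives > 50000 nM, which is a limit of the assay rather than a number.
Compound 2, `CCC(=O)Nc1ncc(-c2ccc(OC)cc2)n1C`, in this assay gives > 100000 nM, again a limit of the assay.
Compound 3, `O=C(Nc1ncc(-c2ccccc2)o1)c1ccc(Cl)cc1`, in this assay gives 10000 nM.

Compound 2 therefore stands at the limit of > 100000 nM in this assay, at which 1 of the 3 values shown sits, so it has no exact value, only the knowledge that it was tolerated up to the highest concentration tested. Compound 1 stands at the limit of > 50000 nM in this assay, at which 1 of the 3 values shown sits, another limit. Only compound 3 gives a measured number. Among the compounds with values here, none of the three measured compounds differs from another in a single place, so no measured step is available to anchor a prediction.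

Compound 4, `COc1ccc(-c2cnc(NC(=O)c3ccccc3)n2C)cc1`, differs from compound 2 by phenyl in place of ethyl on a carbonyl carbon. Compound 1 also carries a phenyl on its carbonyl carbon and gives only a limit in this assay, which suggests that an aromatic amide on the shared core does not by itself bring the tolerated concentration down into the measured range. The step from compound 2 to compound 4 is expected to be small, perhaps toward a somewhat lower tolerated concentration but not clearly beyond the usual scatter, an at least 1.6-fold lower number from compound 2 to compound 4 (0.22 log units; that floor lies within the scatter). Compound 4 is thus estimated at about 60000 nM, with a likely range from 20000 nM to 200000 nM.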

Compound 4, half-maximal cytotoxic concentration: > 100000 nM
Compound 4 was reported as a limit (the forecaster's own chance of this, stated with the estimate: 60%); middle value at least 1.6-fold (0.22 log units) away from the limit.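

In this assay compound 4 gives > 100000 nM, a limit of the assay. Compound 2 sits at that same limit, so no step can be read for phenyl in place of ethyl on a carbonyl carbon: the limit of > 100000 nM in this assay, at which 2 of the 4 values shown sit. The compounds shown leave open whether this change alters the tolerated concentration at all.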